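A few compounds are considered here, and "the series" means these few. Any claim that something is new, unique, unknown or untested is made for them only; others in the source may bear on it.

Measured so far in an assay on isolated protein for inhibition of histone deacetylase 8 (Homo sapiens), read by fluorescence, with a stated time of 90 min; on this read-out lower numbers stand for stronger inhibition and higher numbers for weaker inhibition:

- compound 1 `Cc1cc2cc(NS(=O)(=O)c3cc(C(=O)NO)ccc3Cl)ccc2n(C)c1=O` gives 560 nM
- compound 2 `COc1ccc(C(=O)NO)cc1CS(=O)(=O)Nc1ccc2c(c1)cc(C)c(=O)n2C` gives 158 nM

Compound 2 holds the lower of the two numbers. Compound 1 sits at a higher number, and the gap between the two lies beyond the scatter; the two structures differ in more than one place, so nothing is drawn from that pair as a single step.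

The step now followed leads from compound 2 to compound 3 `Cc1cc2cc(NS(=O)(=O)Cc3cccc(C(=O)NO)c3)ccc2n(C)c1=O`, not yet measured. The change is hydrogen in place of methoxy on an aromatic carbon. Among the measured compounds shown here, no pair of measured compounds shows this change on its own, so there is no measured step to lean on.

Expectation: the loss of the methoxy is taken as a small step in this assay, if any, with a slight lean toward a higher number, within or just beyond the scatter; the expected step is a 1.9-fold higher number from compound 2 to compound 3 (0.28 log units; within the scatter). Compound 3 is estimated at 300 nM, with a range from 100 nM to 1000 nM.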

Compound 3, half-maximal inhibitory concentration: 465 nM
Beside the measured number, compound 3's estimate is 1.6-fold (0.19 log units) below it, and the stated range covers the measured number.
By their numbers in this assay, from the lowest: compound 2; then compounds 3 and 1 (each within the scatter of the next).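

The series now has its first step that isolates a single change: in this assay, hydrogen in place of methoxy gives a 2.9-fold higher number from compound 2 to compound 3 (0.47 log units; beyond the scatter) and so counts as a modest loss of inhibition beyond the scatter. The methoxy on this aromatic carbon, ortho to a large group and para to a hydroxycarbamoyl group, therefore has a measurable bearing on the number in this assay, which the earlier pair, differing in more than one place, could not show. No data bearing on the reason for this step are available.

The compounds shown leave open whether the gain tracks methoxy specifically or would also appear with another group on this carbon, such as a hydroxyl, an ethoxy, an amine or a fluorine. Among the compounds shown here, they also leave open whether the same change carries the same size of step on a compound with a different link between the sulfonamide and the aromatic ring, since this one pair is the only evidence for the change.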